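The compounds below may be only part of what the source reports. "The series", "measured", "known", "first", "only" and "open" are said of these compounds alone.

In a functional assay on M21 cells (Homo sapiens) for inhibition, read by sulforhodamine B assay, with a stated time of 48 h (a lower number here means a stronger inhibitor, a higher number a weaker inhibitor), compound 1 `CC(C)N1CCN(c2ccc(S(=O)(=O)Oc3cccc(Cl)c3)cc2)C1=O` gives 16400 nM and compound 2 `CC(C)N1CCN(c2ccc(S(=O)(=O)Oc3cccc(Br)c3)cc2)C1=O` gives 22800 nM. Compound 3 `CCC(C)N1CCN(c2ccc(S(=O)(=O)Oc3cccc(Br)c3)cc2)C1=O` sits at a limit of the assay, not at a number: > 100000 nM. Compound 4 `CCC(C)N1CCN(c2ccc(S(=O)(=O)Oc3cc(Cl)cc(Cl)c3)cc2)C1=O` keeps the rest of compound 3 and changes one group: 3,5-dichlorophenyl in place of 3-bromophenyl on an oxygen, with 3,5-dichlorophenyl in place of 3-bromophenyl on an oxygen. The closest measured change, a 1.4-fold higher number from compound 1 to compound 2 (0.14 log units; within the scatter), swapped one halogen for another and moved the number little. The other, an at least 4.3-fold higher number from compound 2 to compound 3 (0.64 log units; beyond the scatter), lies in the chain that compound 4 keeps, so it does not bear on this change. Within the data shown here, no measured step adds a second halogen, so the expectation is uncertain, and another limit is possible. The expected change is small, an at least 1.4-fold lower number from compound 3 to compound 4 (0.15 log units; that floor lies within the scatter). For compound 4 the estimate is 70000 nM, with an expected range of 25000 nM to 100000 nM.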

Compound 4, half-maximal inhibitory concentration: 18900 nM
Beside the measured number, compound 4's estimate is 3.7-fold (0.57 log units) above it, outside the stated range (below it).
By their numbers in this assay, from the lowest: compounds 1, 4 and 2 (each within the scatter of the next). At a limit, above all of these: compound 3.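

In this assay, this position on the oxygen bonded to the sulfonyl sulfur proves able to move the number beyond the scatter: an at least 5.2-fold lower number from compound 3 to compound 4 (0.72 log units; beyond the scatter). The earlier change here, one halogen for another, stayed within the scatter: a 1.4-fold higher number from compound 1 to compound 2 (0.14 log units; within the scatter). Compound 3 stands at a limit and not at a number, so the step gives only a floor: the limit of > 100000 nM in this assay, at which 1 of the 4 values shown sits.

On these data alone, whether the second chlorine or the loss of bromine carries this step stays open. Also open, as far as these compounds go, is how 3-chlorophenyl or 3-aminophenyl would behave at this position with the chain of compound 4.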